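This account rests on a few compounds, and the source may have more. Where it says the series, first, only, none or still open, it means among the compounds named here.

Measured in a functional assay on cells (Cancer cell lines, Homo sapiens) for cytotoxicity, with a stated time of 48 h; on this read-out lower numbers stand for stronger inhibition of growth and higher numbers for weaker inhibition of growth:
compound 1 `COc1cc2c(/C=C3/C(=O)Nc4ccc(Cl)cc43)c(Cl)n(Cc3cc(OC)c(OC)c(OC)c3)c2cc1C` gives 2340 nM;
compound 2 `COc1cc2c(/C=C3/C(=O)Nc4cccc(Cl)c43)c(Cl)n(Cc3cc(OC)c(OC)c(OC)c3)c2cc1C` gives 3020 nM;
compound 3 `COc1c(/C=C2/C(=O)Nc3ccccc32)c2ccccc2n1-c1ccccc1` gives 2190 nM.

Compound 1 stands second highest of these three numbers; compound 3 lies nearest to it and compound 2 furthest, and both gaps fall within the scatter. Compound 4 `COc1ccc2c(c1)/C(=C\c1c(Cl)n(Cc3cc(OC)c(OC)c(OC)c3)c3cc(C)c(OC)cc13)C(=O)N2` differs from compound 1 by methoxy in place of chloro on an aromatic carbon. Among the measured compounds shown here, only one measured step, a 1.3-fold higher number from compound 1 to compound 2 (0.11 log units; within the scatter), changes the same part of the molecule, and it stayed within the scatter. For the measured compounds named here, no measured pair swaps chloro for methoxy, so nothing in the data points to a step beyond the scatter in this assay in either direction. Compound 4 is therefore estimated at 2300 nM (range 1000 nM to 5000 nM), and the expected step of a 1.0-fold lower number from compound 1 to compound 4 (0.01 log units; within the scatter) is taken to lie within the scatter.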

Compound 4, concentration for 50% growth inhibition: 16200 nM
Compound 4: the middle estimate sits 7.0-fold (0.85 log units) below what was measured; measured number above the stated range.
By their numbers in this assay, from the lowest: compounds 3, 1 and 2 (each within the scatter of the next); then compound 4.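

In this assay, among the compounds shown here, the group on this aromatic carbon matters: the change to methoxy in place of chloro gives a 6.9-fold higher number from compound 1 to compound 4 (0.84 log units; beyond the scatter), whereas the only earlier step in this part of the molecule, a 1.3-fold higher number from compound 1 to compound 2 (0.11 log units; within the scatter), stayed within the scatter. The number therefore does not hold across every substituent on this ring, and the larger methoxy-bearing compound 4 stands apart from compounds 1, 2 and 3. Nothing measured here accounts for the step.

From the compounds shown here alone, whether fluoro, methyl or an amine on this carbon would track chloro or methoxy stays open. So does whether methoxy elsewhere on this ring would give a similar step.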